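The source may hold more compounds than are shown below. What is called first, only, known or untested is meant among the compounds shown, and "the series" means these compounds.

Measured compounds in an ADME assay on RAW264.7 cells (Mus musculus) for cytotoxicity, read by MTT assay, with a stated time of 24 h, tested at 2.5 ug/mL; a higher number here means a weaker effect of the compound at the concentration tested, a lower number a stronger effect:
compound 1, `COc1ccc(CCCc2ccc(OC)cc2OC)c(O)c1`, gives 97.7%
compound 2, `COc1ccc(C(=O)/C=C/c2ccc(OC)c(OC)c2)c(O)c1`, gives 92.6%
compound 3, `COc1ccc(C(=O)/C=C/c2ccc(OC)c(OC)c2OC)c(O)c1`, gives 96.6%

All three values lie within the scatter of one another, so no order among compound 1, compound 2 and compound 3 is claimed. The difference between the core of compound 1 and the core of compound 2 is not broken down here.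

Between compound 2 and compound 3 the change is methoxy in place of hydrogen on an aromatic carbon, and the step is a number 4 percentage points higher from compound 2 to compound 3 (within the scatter). The same kind of change leads from compound 1 to compound 4, `COc1ccc(CCCc2ccc(OC)c(OC)c2OC)c(O)c1`, namely (methoxy in place of hydrogen on an aromatic carbon). The surroundings differ: in compound 3 the new group sits ortho to a large group, ortho to a methoxy group and meta to a methoxy group, whereas in compound 4 it sits ortho to two methoxy groups and meta to a large group.

For compound 4 the expected step in this assay is a number 0.3 percentage points higher from compound 1 to compound 4 (within the scatter), beside the earlier one, because compound 2 to compound 3 shows a number 4 percentage points higher from compound 2 to compound 3 (within the scatter) and compound 1 already gives 97.7%. Compound 4 is thus estimated at 98%, between 90% and 100%.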

Compound 4, a percentage reported as activity, at one concentration (the size of the read-out at that concentration, not a potency): 95.5%
Beside the measured number, compound 4's estimate is 2.5 percentage points above it; low and high end bracket the measured number.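

In this assay methoxy in place of hydrogen on an aromatic carbon gives a number 2.2 percentage points lower from compound 1 to compound 4 (within the scatter) and this step does not differ from the one on the other core: the same change on two cores in this assay, a number 4 percentage points higher (within the scatter) from compound 2 to compound 3 and a number 2.2 percentage points lower (within the scatter) from compound 1 to compound 4, 6.2 percentage points apart, within the scatter of two such steps.
At the single concentration tested, the two pairs therefore give no sign that the outcome of this change depends on the core. For the compounds shown here, they do not show that the change carries over unaltered, or that it is without effect, as each core supplies only one pair, neither step stands clear of the scatter, and the surroundings of the new methoxy differ between the two cores.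

Still open, on these data alone, is whether a different group on the same aromatic carbon, such as an amine or a carboxylic acid, would shift the read-out beyond the scatter. Also open, as far as these compounds go, is whether a longer chain in place of the link between the two aromatic rings of compound 1 would do so.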